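Swapping the carbamate tail of a piperidine-bearing receptor inhibitor

The source may report more compounds than this note shows. Statements on the series, on what has been measured and on what is new or still open speak of the compounds shown alone.

Of the compounds shown here, two sharing one core have been measured in a functional assay on isolated protein for inhibition of Glucose-dependent insulinotropic receptor (Rattus norvegicus), read by HTRF and cAMP accumulation; a higher number here means a larger maximal response, a lower number a smaller maximal response. Compound 1 `CCC1(OC(=O)N2CCC(Oc3ncnc(Oc4ccc(S(C)(=O)=O)nc4C)c3F)CC2)CC1` gives 83%, and compound 2 `Cc1nc(S(C)(=O)=O)ccc1Oc1ncnc(OC2CCN(C(=O)OC3(C(F)(F)F)COC3)CC2)c1F` gives 84%. Within the data shown here, the single step between them, a number 1 percentage points higher from compound 1 to compound 2 (within the scatter), replaced the 1-ethylcyclopropyl by the 3-(trifluoromethyl)oxetan-3-yl on the oxygen next to the carbonyl group, so compound 2 stands level with compound 1 within the usual scatter.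

Compound 3 `Cc1nc(S(C)(=O)=O)ccc1Oc1ncnc(OC2CCN(C(=S)OC3(C)CC3)CC2)c1F` has not been measured. It differs from compound 2 in one place: a group of 7 heavy atoms (5 carbon, 1 oxygen, 1 sulfur; one three-membered non-aromatic ring of carbon only) in place of a group of 11 heavy atoms (5 carbon, 3 oxygen, 3 fluorine; one four-membered non-aromatic ring with 1 hetero atom), on an amine nitrogen in a ring. The group that leaves is the ((3-(trifluoromethyl)oxetan-3-yl)oxy)carbonyl; the group that enters has no common name and contains one sulfur instead of a carbonyl oxygen. Among the measured compounds shown here, the only step at hand, a number 1 percentage points higher from compound 1 to compound 2 (within the scatter), shows that exchanging the ring attached to that oxygen hardly moved the maximal response. For the measured compounds named here, the exchange of oxygen for sulfur on the carbonyl has no counterpart among the measured compounds, so a somewhat wider uncertainty is warranted. On that basis compound 3 is expected to show about the same maximal response, a change of a number 4 percentage points lower from compound 2 to compound 3 (within the scatter), giving an estimated 80% with a range from 60% to 95%.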

Compound 3, largest response reached (reported as efficacy), in percent of the reference or control that the assay uses: 49%
Beside the measured number, compound 3's estimate is 31 percentage points above it, and the stated range ends above it.
By their numbers in this assay, from the lowest: compound 3; then compounds 1 and 2 (each within the scatter of the next).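

Among these compounds, the nitrogen of the six-membered ring turns out to be far less forgiving than the first pair of compounds suggested: in this assay the response falls sharply, a number 35 percentage points lower from compound 2 to compound 3 (beyond the scatter) and a number 34 percentage points lower from compound 1 to compound 3 (beyond the scatter), although exchanging the ring on the oxygen had left it within the scatter. The drop from compound 1 matters most, since compound 1 and compound 3 both carry a three-membered ring of carbon only, so keeping that ring type does not preserve the response. Even so, the group in compound 3 differs from that of compound 1 in two ways, with a sulfur in place of the carbonyl oxygen and 7 heavy atoms instead of 8, and no information on why the response falls bears on this result.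

The compounds shown therefore leave open whether the sulfur or the smaller group accounts for the loss, a question that a sulfur-bearing analogue keeping the 1-ethylcyclopropyl could help settle. From the compounds shown here alone, how the response would change with an amine nitrogen in place of the oxygen, which would make the group a urea, also remains open.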